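Aryl swap on the core: pyridin-3-yl to 3,5-difluorophenyl

The source may hold more compounds than are shown below. What is called first, only, known or untested is meant among the compounds shown, and "the series" means these compounds.

Compound 1 `C[C@H](Nc1ncnc2[nH]cnc12)c1nn(-c2cccnc2)c2cc(F)ccc12` was tested in a functional assay on Bel-7402 cells (Homo sapiens) for inhibition, read by sulforhodamine B assay, with a stated time of 72 h; a higher number here means a weaker inhibitor, a lower number a stronger inhibitor. In this assay compound 1 returns only a limit of the assay, > 40000 nM. Compound 2 `CC(C)[C@H](Nc1ncnc2[nH]cnc12)c1nn(-c2cccnc2)c2cc(F)ccc12` likewise returns only a limit in this assay, > 40000 nM. The step that the two limits leave unreadable from compound 1 to compound 2 therefore shows nothing of its size, since the limit of > 40000 nM in this assay, at which 2 of the 2 values shown sit, holds both values at the limit. Compound 3 `C[C@H](Nc1ncnc2[nH]cnc12)c1nn(-c2cc(F)cc(F)c2)c2cc(F)ccc12` differs from compound 1 by 3,5-difluorophenyl in place of pyridin-3-yl on an aromatic nitrogen. No readable measured step bears on this change. Compound 3 is expected to stay at the limit as well, an estimated step of a number no higher from compound 1 to compound 3 (the limit leaves the size open). The estimate for compound 3 is 40000 nM, within 15000 nM to 120000 nM.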

Compound 3, half-maximal inhibitory concentration: > 40000 nM
Compound 3: no number, only a limit (the forecaster's own chance of this, stated with the estimate: 80%); the middle value sits exactly at the limit.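

No step can be read from compound 1 to compound 3, since both stay at a limit in this assay: the limit of > 40000 nM in this assay, at which 3 of the 3 values shown sit.
From the compounds shown here alone, whether any change on the shared core gives measurable inhibition remains open.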